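Trimming the amide of compound 1 to a diethylamide

This account rests on a few compounds, and the source may have more. Where it says the series, first, only, none or still open, it means among the compounds named here.

The measured compounds: compound 1 `CCN(CC)S(=O)(=O)c1ccc(S(=O)(=O)N2CCC[C@@H](C(=O)NC3CN(C(=O)OC(C)(C)C)C3)C2)cc1` gives 100 nM in a functional assay on MIA PaCa-2 cells (Homo sapiens) for inhibition, read by MTT assay, with a stated time of 3 days; a higher number here means a weaker inhibitor, a lower number a stronger inhibitor. Compound 2 `CCOC(=O)N1CCC[C@H](S(=O)(=O)c2ccc(S(=O)(=O)N(CC)CC)cc2)C1` reaches only a limit in this assay, > 10000 nM. Compound 3 `CCOC(=O)[C@@H]1CCCN(C(=O)c2ccc(S(=O)(=O)N(CC)CC)cc2)C1` likewise reaches only a limit in this assay, > 3000 nM.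

Going by the values given here, compound 1 thus holds the only numerical value among the three. Compound 2 sits at the limit of > 10000 nM in this assay, at which 1 of the 3 values shown sits. Compound 3 sits at the limit of > 3000 nM in this assay, at which 1 of the 3 values shown sits.

Compound 4 `CCN(CC)C(=O)[C@@H]1CCCN(S(=O)(=O)c2ccc(S(=O)(=O)N(CC)CC)cc2)C1` differs from compound 1 in one place: diethylamino in place of (1-(tert-butoxycarbonyl)azetidin-3-yl)amino on a carbonyl carbon. Among the compounds with values here, no pair of measured compounds differs in a single place, so the size of this step cannot be read from a measured step. Compound 3, which also lacks the (1-(tert-butoxycarbonyl)azetidin-3-yl)amino group, sits at the limit of > 3000 nM in this assay, at which 1 of the 3 values shown sits; compound 2 sits at the limit of > 10000 nM in this assay, at which 1 of the 3 values shown sits. Both measured compounds without that group give only limits, so a loss beyond the scatter is expected for compound 4. The step of a 15-fold higher number from compound 1 to compound 4 (1.18 log units; beyond the scatter) is estimated as a clear weakening. Compound 4 is expected at 1500 nM, within 300 nM to 10000 nM, with a real chance that only a limit is reported.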

Compound 4, half-maximal inhibitory concentration: 700 nM
Estimate against measurement, compound 4: 2.1-fold (0.33 log units) above, within the range that was stated.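

Replacing (1-(tert-butoxycarbonyl)azetidin-3-yl)amino with diethylamino on the carbonyl carbon weakens the result in this assay, giving a 7.0-fold higher number from compound 1 to compound 4 (0.85 log units; beyond the scatter). The larger group is therefore not needed for a numerical value at this position, as compound 4 still gives 700 nM rather than a limit. The compounds shown offer no measured property that accounts for the size of this step.

As far as these compounds go, it remains open which part of the departing group carries the difference: the four-membered ring, the tert-butoxycarbonyl group or the amide hydrogen. An azetidin-3-ylamino group with a free ring amine, or a plain ethylamino group, on the same carbonyl carbon would begin to separate these parts.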